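Replacing the Unsaturated Chain of Compound 2 with Propyl

The compounds below may be only part of what the source reports. "The series", "measured", "known", "first", "only" and "open" are said of these compounds alone.

Compound 1 `Cc1cccc(Cn2c(CN3CCN(C(=O)c4ccc([N+](=O)[O-])cc4)CC3)nc3ccccc32)c1` gives 24.3% in an assay on isolated protein for inhibition of aldehyde dehydrogenase 1A1 (Homo sapiens), read by spectrophotometry, tested at 10 uM; on this read-out higher numbers stand for more inhibition at the one concentration tested (going by the name of the read-out) and lower numbers for less inhibition.
Compound 2 `CC(C)=CCn1c(CN2CCN(C(=O)C3CC3)CC2)nc2ccccc21` gives 74.3% in this assay.
Compound 3 `Cc1cccc(Cn2c(CN3CCN(C(=O)c4ccc(C(F)(F)F)cc4)CC3)nc3ccccc32)c1` gives 22.9% in this assay.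

Compound 2 stands highest of the three; compound 1 and compound 3 both lie lower by margins beyond the scatter. Going by the values given here, the one measured step, a number 1.4 percentage points lower from compound 1 to compound 3 (within the scatter), swaps a group on an aromatic carbon elsewhere in the structure and so does not bear on the change at hand. Compound 4 `CCCCn1c(CN2CCN(C(=O)C3CC3)CC2)nc2ccccc21` differs from compound 2 in one place: propyl in place of 2-methylprop-1-en-1-yl on a saturated chain carbon bound to an aromatic nitrogen. Among the compounds with values here, with no measured step of this kind, the expectation rests on compound 2 alone: the step of a number 14.3 percentage points lower from compound 2 to compound 4 (beyond the scatter) is expected to be modest, more likely downward than upward, with a wide range. Compound 4 is therefore estimated at 60%, between 35% and 85%.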

Compound 4, a percentage reported as inhibition, at one concentration (the size of the read-out at that concentration, not a potency): 18.2%
Compound 4: the middle estimate sits 41.8 percentage points above what was measured, outside the stated range (below it).
By their numbers in this assay, from the lowest: compounds 4, 3 and 1 (each within the scatter of the next); then compound 2.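

In this assay, propyl in place of 2-methylprop-1-en-1-yl on a saturated chain carbon bound to an aromatic nitrogen gives a number 56.1 percentage points lower from compound 2 to compound 4 (beyond the scatter). This position is therefore highly sensitive to the change, and the rest of the structure, shared by the pair, does not by itself carry the inhibition. Nothing measured here accounts for this step.

The compounds shown do not separate the loss of the double bond from the loss of the branching. From the compounds shown here alone, how a 3-methylbutyl or a but-2-en-1-yl chain would read at this place remains open.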